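Hydroxyphenyl in Place of Bromophenyl on the Imine

A few compounds are considered here, and "the series" means these few. Any claim that something is new, unique, unknown or untested is made for them only; others in the source may bear on it.

Compound 1 `C(=N/c1nnc(SCc2c[se]c(-c3ccccc3)n2)s1)\c1ccccc1` carries an unsubstituted phenyl on the imine carbon of the shared core, and in a functional assay on L1210 cells (Mus musculus) for antiproliferative activity, read by CCK-8 assay (on this read-out lower numbers stand for stronger inhibition and higher numbers for weaker inhibition), compound 1 gives 46500 nM. Compound 2 `Brc1ccc(/C=N/c2nnc(SCc3c[se]c(-c4ccccc4)n3)s2)cc1` has bromo in place of hydrogen on an aromatic carbon, and in this assay compound 2 gives 46500 nM, a step of no change at the digits printed from compound 1 to compound 2 (within the scatter). For the measured compounds named here, compound 2 therefore stands level with compound 1, its only measured neighbour. Compound 3 `Oc1ccccc1/C=N/c1nnc(SCc2c[se]c(-c3ccccc3)n2)s1` differs from compound 2 by 2-hydroxyphenyl in place of 4-bromophenyl on a carbon with a double bond to nitrogen. Going by the values given here, the only step that bears on this change is the one from compound 1 to compound 2, which was flat, so the shared core appears to tolerate exchange on this aromatic ring without a shift beyond the scatter. On that basis the step to compound 3 is expected to be no change at the digits printed from compound 2 to compound 3 (within the scatter) in this assay. Compound 3 is accordingly estimated at 46500 nM, with a range from 20000 nM to 100000 nM.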

Compound 3, half-maximal inhibitory concentration: 38700 nM
Estimate against measurement, compound 3: 1.2-fold (0.08 log units) above; the measured number falls inside the stated range.
By their numbers in this assay, from the lowest: compounds 3, 1 and 2 (each within the scatter of the next).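

In this assay, replacing 4-bromophenyl with 2-hydroxyphenyl on a carbon with a double bond to nitrogen gives a 1.2-fold lower number from compound 2 to compound 3 (0.08 log units; within the scatter), and setting 2-hydroxyphenyl against the unsubstituted phenyl gives a 1.2-fold lower number from compound 1 to compound 3 (0.08 log units; within the scatter). The entering 2-hydroxyphenyl counts a hydrogen-bond donor and acceptor that 4-bromophenyl lacks, yet this exchange leaves the number within the scatter, just as the bromo step did, so the three compounds do not separate at this position. No measurement is at hand that would explain this lack of separation.

On these data alone, whether an amine or a carboxylic acid on this aromatic ring would move the number beyond the scatter remains open. All three compounds also share the rest of the core, so the effect of changes there is equally unknown.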